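The source may hold more compounds than are shown below. What is called first, only, known or untested is meant among the compounds shown, and "the series" means these compounds.

For the measured compounds named here, in an ADME assay on RAW264.7 cells (Mus musculus) for cytotoxicity, read by MTT assay, with a stated time of 24 h (a higher number here means that more compound is tolerated, a lower number that less compound is tolerated), compound 2 (`CC/C=C\C[C@H]1C(=O)C=C[C@H]1CC(=O)OCc1ccccc1`) gives 31 uM, the lower of the two numbers so far, against compound 1 (`CC/C=C\C[C@H]1C(=O)C=C[C@H]1CC(=O)OCC`) at 146 uM. Compound 3 (`CC/C=C\C[C@H]1C(=O)C=C[C@H]1CC(=O)OCCOCCOCCO`) has (2-(2-hydroxyethoxy)ethoxy)methyl in place of phenyl on a saturated chain carbon bound to an oxygen next to a carbonyl group. Going by the values given here, the only measured step that bears on this is phenyl in place of methyl, a 4.7-fold lower number from compound 1 to compound 2 (0.67 log units; beyond the scatter). As far as these compounds go, compound 3 lacks that phenyl, but its chain is untested, so a step of similar size towards a higher number is expected: a 4.2-fold higher number from compound 2 to compound 3 (0.62 log units; beyond the scatter). Compound 3 is estimated at 130 uM, with an expected range of 50 uM to 350 uM.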

Compound 3, half-maximal toxic concentration: 162 uM
For compound 3 the middle estimate is 1.2-fold (0.10 log units) below the measured one; the range from low to high includes it.
By their numbers in this assay, from the lowest: compound 2; then compounds 1 and 3 (each within the scatter of the next).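

In this assay, replacing phenyl with (2-(2-hydroxyethoxy)ethoxy)methyl gives a 5.2-fold higher number from compound 2 to compound 3 (0.72 log units; beyond the scatter), so the lower number of compound 2 does not carry over to this open chain. Placing 2-(2-hydroxyethoxy)ethoxy in place of hydrogen gives a 1.1-fold higher number from compound 1 to compound 3 (0.05 log units; within the scatter), so this position accepts the chain with no step beyond the scatter. Nothing at hand accounts for either step. Still open, as far as these compounds go, is whether the lower number belongs to phenyl specifically or to ring-bearing groups generally, which a cyclohexyl or pyridyl group could test. From the compounds shown here alone, a terminal amine or carboxylic acid on the chain also remains open.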